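Chain and Heteroatom Swap at the Ether Position

This account rests on a few compounds, and the source may have more. Where it says the series, first, only, none or still open, it means among the compounds named here.

Measured compounds:
compound 1, `CCCCCCCCOc1nc(N)nc2c1ncn2/C=C1/CC1(CO)CO`: > 20000 nM
compound 2, `CCCOc1nc(N)nc2c1ncn2/C=C1/CC1(CO)CO`: > 20000 nM

In an ADME assay on Akata cells (Homo sapiens) for cytotoxicity, with a stated time of 7 days (on this read-out higher numbers stand for lower toxicity in this test and lower numbers for higher toxicity in this test), compound 1 reaches only a limit of the test, > 20000 nM. Compound 2 likewise stands at a limit, > 20000 nM. The step that the two limits leave unreadable from compound 1 to compound 2 is therefore not readable, and the whole evidence is the limit of > 20000 nM in this assay, at which 2 of the 2 values shown sit. Compound 3, `CCCCCCSc1nc(N)nc2c1ncn2/C=C1/CC1(CO)CO`, carries hexylsulfanyl in place of octyloxy on an aromatic carbon. Among the measured compounds shown here, no measured step bears on a change of this kind, and compound 1 itself is known only as a limit, so no step beyond the scatter can be anticipated in either direction in this assay. Compound 3 is expected to give 30000 nM, between 15000 nM and 80000 nM, which would be an expected step that the limit leaves unreadable from compound 1 to compound 3.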

Compound 3, half-maximal cytotoxic concentration: > 20000 nM
Compound 3 ended at the assay's limit (the forecaster's own chance of this, stated with the estimate: 85%); the middle value is on the limit's open side.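

No step can be read from compound 1 or compound 2 to compound 3, as all three compounds sit at a limit: the limit of > 20000 nM in this assay, at which 3 of the 3 values shown sit. The compounds shown leave open where their half-maximal cytotoxic concentrations lie and whether hexylsulfanyl in place of octyloxy changes them.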